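The source may hold more compounds than are shown below. What is called first, only, known or untested is meant among the compounds shown, and "the series" means these compounds.

Measured compounds:
compound 1 `COc1ccc(C(=O)c2cc(OC)c(OC)c(OC)c2)cc1NC(=O)/C=C/c1cc(OC)c(OC)c(OC)c1` gives 2100 nM
compound 2 `COc1cccc(/C=C/C(=O)Nc2cc(C(=O)c3cc(OC)c(OC)c(OC)c3)ccc2OC)c1` gives 4300 nM

For the measured compounds named here, in a functional assay on ME-180 cells (Homo sapiens) for cytotoxicity, read by MTT assay, with a stated time of 72 h (on this read-out higher numbers stand for weaker inhibition and lower numbers for stronger inhibition), compound 1 holds the lower of the two numbers; the step of a 2.0-fold higher number from compound 1 to compound 2 (0.31 log units; beyond the scatter) is the only measured comparison. Compound 3 `COc1cc(C(=O)c2cc(OC)c(OC)c(OC)c2)cc(NC(=O)/C=C/c2cc(OC)c(OC)c(OC)c2)c1OC` differs from compound 1 by methoxy in place of hydrogen on an aromatic carbon. Going by the values given here, the measured step concerns the aryl group on the double-bonded chain carbon and does not touch the ring that carries the added group, so no measured step bears directly on this change. Compound 3 is therefore expected near compound 1, with a step of a 1.2-fold higher number from compound 1 to compound 3 (0.08 log units; within the scatter) not beyond the scatter. The estimate for compound 3 is 2500 nM, range 1000 nM to 6500 nM.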

Compound 3, half-maximal inhibitory concentration: 3900 nM
Beside the measured number, compound 3's estimate is 1.6-fold (0.19 log units) below it; the range from low to high includes it.
By their numbers in this assay, from the lowest: compounds 1, 3 and 2 (each within the scatter of the next, the first and the last beyond it).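

In this assay, methoxy in place of hydrogen on an aromatic carbon, ortho to a methoxy group and meta to two large groups, gives a 1.9-fold higher number from compound 1 to compound 3 (0.27 log units; within the scatter). For the compounds shown here, this is the first reading on the ring carrying the added group, as the earlier step concerned only the aryl group on the chain, and at this position the added methoxy stays within the scatter. Nothing available explains this result.

Open, on these data alone, is whether an amine or a longer alkoxy chain at this position would also stay within the scatter of compound 1. Also open, as far as these compounds go, is whether the added methoxy would read the same with the 3-methoxyphenyl group of compound 2.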